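A few compounds are considered here, and "the series" means these few. Any claim that something is new, unique, unknown or untested is made for them only; others in the source may bear on it.

Of the compounds shown here, three sharing one core have been tested in an ADME assay on Caco-2 cells (Homo sapiens) for permeability, in the apical to basolateral direction; a lower number here means that the compound crosses the layer more slowly, a higher number that the compound crosses the layer faster. Compound 1 `Cn1cncc1CN1CC(N(CC2CCN(C(=O)C(C)(C)C)CC2)S(=O)(=O)c2ccccn2)Cc2cc(C#N)ccc21` gives 0.5 10^-6 cm/s in this assay. Compound 2 `Cn1cncc1CN1CC(N(CC2CCN(C(=O)CC(C)(C)C)CC2)S(=O)(=O)c2ccccn2)Cc2cc(C#N)ccc21` gives 0.5 10^-6 cm/s. Compound 3 `Cn1cnc(S(=O)(=O)N(Cc2cccc(-n3cccc3)c2)C2Cc3cc(C#N)ccc3N(Cc3cncn3C)C2)c1` gives 0.2 10^-6 cm/s. Going by the values given here, the single step between neighbours that differ in one place, no change at the digits printed from compound 1 to compound 2 (within the scatter), shows that putting a neopentyl in place of a tert-butyl on the carbonyl carbon left the number where it was. Compound 2 therefore stands level with compound 1, the two together forming the higher pair of the three numbers, while compound 3 sits lower by a margin beyond the scatter.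

Compound 4 `CCOC(=O)N1CCC(CN(C2Cc3cc(C#N)ccc3N(Cc3cncn3C)C2)S(=O)(=O)c2ccccn2)CC1` has not yet been measured. It differs from compound 2 in one place: ethoxy in place of neopentyl on a carbonyl carbon. Among the compounds with values here, the only measured step that touches this carbonyl carbon is no change at the digits printed from compound 1 to compound 2 (within the scatter), and it was flat; no measured step exchanges a carbon chain for an ethoxy group at this position, so the evidence is thin. Within the data shown here, with all three measured numbers low and the one relevant step flat, the change is expected to produce no step beyond the scatter. For compound 4 the expected step is a 1.3-fold lower number from compound 2 to compound 4 (0.10 log units; within the scatter). Compound 4 is accordingly estimated to give about 0.4 10^-6 cm/s, most likely between 0.2 10^-6 cm/s and 0.9 10^-6 cm/s.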

Compound 4, apparent permeability: 2.6 10^-6 cm/s
Estimate against measurement, compound 4: 6.5-fold (0.81 log units) below; the whole stated range lies below it.
By their numbers in this assay, from the lowest: compound 3; then compounds 1 and 2 (each within the scatter of the next); then compound 4.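

In this assay the group on this carbonyl carbon clearly matters, even though exchanging one all-carbon group for another had left the number unmoved. Ethoxy in place of neopentyl brings a 5.2-fold higher number from compound 2 to compound 4 (0.72 log units; beyond the scatter) and ethoxy in place of tert-butyl brings a 5.2-fold higher number from compound 1 to compound 4 (0.72 log units; beyond the scatter) so the same rise appears from either all-carbon group, and a neopentylcarbonyl to ethoxycarbonyl exchange is a real change at this site rather than a minor edit. No measurement shown accounts for this rise.

The exchange also alters two things at once: ethoxy has 3 heavy atoms against 5 in neopentyl, and it adds an oxygen that counts as a hydrogen-bond acceptor, so these compounds cannot say which of the two differences goes with the higher number. A propyl chain on the same carbonyl carbon would keep a similar length without the oxygen, while a methoxy group, a longer propoxy group or an ethylamino group would show whether the rise holds across related groups or belongs to ethoxy alone.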